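Hydroxy entry on fluorinated pairs at the assay limit

This account rests on a few compounds, and the source may have more. Where it says the series, first, only, none or still open, it means among the compounds named here.

Measured so far:
Compound 1 `O=C(/C=C/c1ccccc1F)c1ccccc1`: in a functional assay on RAW264.7 cells (Mus musculus) for inhibition, read by fluorescence, with stated times of 1 h, 24 h and 30 min (a higher number here means a weaker inhibitor, a lower number a stronger inhibitor), compound 1 reaches only the limit, > 10000 nM.
Compound 2 `O=C(/C=C/c1ccccc1F)c1ccccc1O`: in this assay compound 2 also stays at a limit, > 10000 nM.
Compound 3 `O=C(/C=C/c1ccc(F)cc1)c1ccccc1`: in this assay compound 3 likewise gives only a limit, > 10000 nM.

The change from compound 1 to compound 2 is hydroxy in place of hydrogen on an aromatic carbon; its step is a step that the two limits leave unreadable from compound 1 to compound 2, since every value in the series sits at the limit of > 10000 nM in this assay, at which 3 of the 3 values shown sit. Compound 3 has the same atoms as compound 1, joined differently; the difference between the two cores is not broken down here. Compound 4 `O=C(/C=C/c1ccc(F)cc1)c1ccc(O)cc1` remains to be measured. It arises from compound 3 by hydroxy in place of hydrogen on an aromatic carbon, the same kind of change as from compound 1 to compound 2, though there the hydroxy sits ortho to a large group and here para to a large group. The step that the limit leaves unreadable from compound 3 to compound 4 is expected to be small, as the earlier one left no readable size. Compound 4 is expected near 15000 nM, between 4000 nM and 60000 nM, most probably again reported only as a limit.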

Compound 4, half-maximal inhibitory concentration: > 10000 nM
Compound 4: only a limit was reported; the forecaster's own chance of this, stated with the estimate: 75%; the middle value does not contradict the limit.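

No step can be read from compound 3 to compound 4, as both give only a limit: the limit of > 10000 nM in this assay, at which 4 of the 4 values shown sit.

The compounds shown leave open whether hydroxy in place of hydrogen on an aromatic carbon changes inhibition at all; none of them yields a number.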